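Swapping the open-chain tail on a shared core

A few compounds are considered here, and "the series" means these few. Any claim that something is new, unique, unknown or untested is made for them only; others in the source may bear on it.

Three measured compounds share one core and differ only in the group on a saturated chain carbon bound to a saturated ring carbon. Compound 1 `O=S(=O)(c1cccc(F)c1)c1ccc2c(c1)CCC[C@H]2CN1CCCS1(=O)=O` carries a ring-containing group there and in an assay on isolated protein for displacement of a labelled ligand from 5-hydroxytryptamine receptor 6 (Homo sapiens) (on this read-out lower numbers stand for stronger inhibition and higher numbers for weaker inhibition), gives 31.6 nM. Compound 2 `O=C(NC[C@@H]1CCCc2cc(S(=O)(=O)c3cccc(F)c3)ccc21)[C@H]1CCCN1` gives 0.631 nM, and compound 3 `CNCC(=O)NC[C@@H]1CCCc2cc(S(=O)(=O)c3cccc(F)c3)ccc21` gives 0.159 nM, the lowest of the three numbers. The exchanges at this position are a 50-fold lower number from compound 1 to compound 2 (1.70 log units; beyond the scatter) and a 200-fold lower number from compound 1 to compound 3 (2.30 log units; beyond the scatter), both large, while a 4.0-fold lower number from compound 2 to compound 3 (0.60 log units; beyond the scatter) is modest.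

Compound 4 `N=C(N)NC(=O)C[C@@H]1CCCc2cc(S(=O)(=O)c3cccc(F)c3)ccc21` has not yet been measured in this assay. Relative to compound 3 the change is a group of 6 heavy atoms (2 carbon, 3 nitrogen, 1 oxygen; no ring) in place of a group of 6 heavy atoms (3 carbon, 2 nitrogen, 1 oxygen; no ring), on a saturated chain carbon bound to a saturated ring carbon. Within the data shown here, none of the measured steps exchanges one open-chain group of this kind for another; the nearest comparison is the modest step from compound 2 to compound 3, where a carbonyl-linked group with one nitrogen donor set was replaced by another. The two large steps away from compound 1 show that this position can move the number strongly, but compound 2 and compound 3 sit close together, so a modest move is expected here, with a 6.3-fold higher number from compound 3 to compound 4 (0.80 log units; beyond the scatter) toward a somewhat higher number. For compound 4 the estimate in this assay is 1 nM, expected to lie between 0.25 nM and 4 nM.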

Compound 4, inhibition constant: 0.631 nM
For compound 4 the middle estimate is 1.6-fold (0.20 log units) above the measured one; low and high end bracket the measured number.
By their numbers in this assay, from the lowest: compound 3; then compounds 2 and 4 (each within the scatter of the next); then compound 1.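

In this assay, among these compounds, compound 4 gives the first exchange at this position between two ring-free groups of the same size, 6 heavy atoms each, and it still produces a 4.0-fold higher number from compound 3 to compound 4 (0.60 log units; beyond the scatter), so these two compounds show that the number depends on which atoms make up the group and not only on how many there are. The group in compound 4 also needs no ring to match the ring-bearing group of compound 2, since no change at the digits printed from compound 2 to compound 4 (within the scatter), which means that among these compounds the five-membered ring of compound 2 is not required to reach that level. With a 50-fold lower number from compound 1 to compound 4 (1.70 log units; beyond the scatter), compound 4 becomes the third group to leave the sulfur-containing ring of compound 1 behind with a large drop in the number, and compounds 2, 3 and 4 all show that drop despite their different groups.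

The compounds shown leave open how a simple primary amine, a carboxylic acid or a longer carbon chain would read at this same place, and so which part of the group in compound 4 matters for the number. Nothing measured here accounts for the size of these steps.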